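Fluorine on the Phenyl Ring and Liver Microsome Stability

The compounds below may be only part of what the source reports. "The series", "measured", "known", "first", "only" and "open" are said of these compounds alone.

Three compounds built on a common core were measured in an ADME assay on microsomes from liver (Homo sapiens) for metabolic stability, with a stated time of 10 min, tested at 0.5 uM; a higher number here means that more of the compound is left, a lower number that less of the compound is left. Compound 1 `Cc1noc(C)c1[C@@H]1C[C@@](C)(c2ccccc2)N=C(N)S1` gives 86%. Compound 2 `Cc1noc(C)c1[C@@H]1C[C@@](C)(c2ccc(F)cc2)N=C(N)S1` differs from compound 1 by a single change, (fluoro in place of hydrogen on an aromatic carbon), and in this assay compound 2 gives 73%. That change produced a step of a number 13 percentage points lower from compound 1 to compound 2 (beyond the scatter). Compound 3 `Cc1onc(-c2ccccc2)c1[C@@H]1C[C@@](C)(c2ccc(F)cc2F)N=C(N)S1` carries a different core, and the difference between the two cores is not broken down here. In this assay compound 3 gives 38%, which is the lowest of the three numbers, with its nearest neighbour being compound 2 and the furthest compound 1.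

Compound 4 `Cc1onc(-c2ccc(F)cc2)c1[C@@H]1C[C@@](C)(c2ccc(F)cc2F)N=C(N)S1` is not yet measured. It differs from compound 3 by fluoro in place of hydrogen on an aromatic carbon, and the description of where the change sits reads the same, word for word, as for the change from compound 1 to compound 2. The same change is therefore being made a second time, now on the core of compound 3, which starts from a lower level. The expected step for compound 4 is a number 11 percentage points lower from compound 3 to compound 4 (beyond the scatter), resting on the earlier step of a number 13 percentage points lower from compound 1 to compound 2 (beyond the scatter) seen on the other core. Compound 4 is accordingly estimated at 27% in this assay, expected to lie between 12% and 42%.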

Compound 4, percent of the compound remaining: 24%
Beside the measured number, compound 4's estimate is 3 percentage points above it; the measured number falls inside the stated range.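

In this assay, replacing phenyl with 4-fluorophenyl gave a number 14 percentage points lower from compound 3 to compound 4 (beyond the scatter), so less of the compound was left after fluoro entered on an aromatic carbon, para to a large group. Set beside the earlier step, the change shows much the same size on the two cores, even though the second step starts from a lower level: the same change on two cores in this assay, a number 13 percentage points lower (beyond the scatter) from compound 1 to compound 2 and a number 14 percentage points lower (beyond the scatter) from compound 3 to compound 4, 1 percentage points apart, within the scatter of two such steps. Among these compounds, this agreement rests on only two pairs, and it does not show why the number falls or that the step would hold on any further core; the structures also show that the ring gaining fluoro in compound 4 is not the counterpart of the ring gaining it in compound 2, so the match concerns the same kind of change rather than the same site.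

The compounds shown leave open whether another group in the same place, such as chloro, methoxy or an amine, would move the number in the same direction or by a similar amount. They also leave open whether a carboxylic acid or a longer chain there would keep more of the compound in this measurement.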